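Adding an Isobutyl Arm to Compound 1

The source may report more compounds than this note shows. Statements on the series, on what has been measured and on what is new or still open speak of the compounds shown alone.

Compound 1 `O=C(CN(c1nc(Cl)nc2[nH]cnc12)C1CC1)NCC(=O)OCc1ccccc1`, compound 2 `O=C(O)CNC(=O)CN(c1nc(Cl)nc2[nH]cnc12)C1CC1` and compound 3 `O=C(O)C[C@H](NC(=O)CN(c1nc(Cl)nc2[nH]cnc12)C1CC1)C(=O)O` share one core. In a functional assay on the whole organism (Tail, strain ICR) with Mus musculus as the target, in the tail flick test, with a stated time of 90 min, at a dose of 25 umol/kg by the oral route (a lower number here means a weaker effect, a higher number a stronger effect of the compound at the dose given), compound 1 gives 27.2%, compound 2 gives 32.3% and compound 3 gives 25.1%; all three numbers lie within the scatter of one another, so compound 1 cannot be ranked against the other two, and a number 5.1 percentage points higher from compound 1 to compound 2 (within the scatter). Compound 4 `CC(C)C[C@H](NC(=O)CN(c1nc(Cl)nc2[nH]cnc12)C1CC1)C(=O)OCc1ccccc1` differs from compound 1 by isobutyl in place of hydrogen on a saturated chain carbon bound to an amide-type nitrogen and a carbonyl carbon. The step that bears on this change is a number 7.2 percentage points lower from compound 2 to compound 3 (within the scatter), where a different group entered on a saturated chain carbon bound to an amide-type nitrogen and a carbonyl carbon and the number stayed within the scatter. A similar outcome is therefore expected, with a number 0.8 percentage points higher from compound 1 to compound 4 (within the scatter). Compound 4 is estimated at 28%, in the range 14% to 42%.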

Compound 4, a percentage reported as activity, at one dose (the size of the read-out at that dose, not a potency): 15.2%
Compound 4: middle estimate off by 12.8 percentage points, on the high side; measured number inside the range.
By their numbers in this assay, from the lowest: compounds 4, 3, 1 and 2 (each within the scatter of the next, the first and the last beyond it).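

In this assay, isobutyl on this saturated chain carbon gives a number 12 percentage points lower from compound 1 to compound 4 (beyond the scatter), so a group placed here can move the number beyond the scatter. The earlier carboxymethyl change at this carbon did not show this, giving a number 7.2 percentage points lower from compound 2 to compound 3 (within the scatter). Nothing available explains the lower number for compound 4. Still open, going by these compounds, is whether a smaller group such as methyl at this carbon would lower the number as well. Also open, on these data alone, is how a chain ending in an amine would behave here.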